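Carbamoyl to Cyano on the Amino-Bearing Carbon

The compounds below may be only part of what the source reports. "The series", "measured", "known", "first", "only" and "open" are said of these compounds alone.

Measured compounds:
Compound 1, `NC(=O)C(N)CCSCCCCC(=O)O`: 17%
Compound 2, `CS(=O)(=O)NC(=O)C(N)CCSCCCCC(=O)O`: 67%
Compound 3, `COC(=O)C(N)CCSCCCCC(=O)O`: "not determined" (no result reported)

Three compounds sharing the same chain were examined in an assay on isolated protein for inhibition of betaine--homocysteine S-methyltransferase 1 (Homo sapiens), with a stated time of 30 min, tested at 20 uM; a lower number here means less inhibition, a higher number more inhibition at the concentration tested (going by the name of the read-out). Compound 1 `NC(=O)C(N)CCSCCCCC(=O)O` gives 17%, the lowest of the two reported numbers. Going by the values given here, compound 2 `CS(=O)(=O)NC(=O)C(N)CCSCCCCC(=O)O` gives 67%, and the only step among the measured compounds is a number 50 percentage points higher from compound 1 to compound 2 (beyond the scatter). Among the compounds with values here, compound 3 `COC(=O)C(N)CCSCCCCC(=O)O` carries a methyl ester in place of the amide but gives "not determined" (no result reported), so it contributes no step.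

Compound 4 `N#CC(N)CCSCCCCC(=O)O` differs from compound 1 in one place: cyano in place of carbamoyl on a saturated chain carbon bound to an amine nitrogen and a saturated chain carbon

Within the data shown here, no measured step concerns this change. Among the measured compounds shown here, the single step, from an amide hydrogen to a methylsulfonyl group on the amide-type nitrogen, was large, but it does not involve replacing the carbamoyl group itself, and compound 3, the only other variation at this position, gives no number. The expectation for compound 4 therefore rests on compound 1 alone, and no step beyond the scatter is expected in this assay, in either direction: the estimated step is a number 2 percentage points lower from compound 1 to compound 4 (within the scatter). Compound 4 is estimated at 15%, within a range from 0% to 40%.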

Compound 4, a percentage reported as inhibition, at one concentration (the size of the read-out at that concentration, not a potency): 9%
The estimate for compound 4 lay 6 percentage points above the measured number; measured number inside the range.
By their numbers in this assay, from the lowest: compounds 4 and 1 (each within the scatter of the next); then compound 2.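

Going by these compounds alone, compound 4 gives the first reading of a change to the carbamoyl group itself: in this assay, cyano in place of carbamoyl on this saturated chain carbon gives a number 8 percentage points lower from compound 1 to compound 4 (within the scatter), so this read-out does not separate the two groups. The earlier compounds shown here showed that this end of the molecule can respond strongly, with a number 50 percentage points higher from compound 1 to compound 2 (beyond the scatter) when methylsulfonyl stands on the amide-type nitrogen, whereas the exchange for cyano, which has fewer heavy atoms and no hydrogen-bond donor, leaves the number within the scatter. No measurement is available that explains either outcome.

With both compound 1 and compound 4 near the low end of the reported numbers, the compounds shown leave open whether any other replacement of the carbamoyl group, such as a carboxylic acid or a tetrazole, would give a number beyond the scatter from that of compound 1. They also leave open whether the higher number of compound 2 is specific to methylsulfonyl or would recur with another group on the amide-type nitrogen, such as phenylsulfonyl or acetyl.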